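Changing the Aryl Group on the Alkyne of Compound 3

The compounds below may be only part of what the source reports. "The series", "measured", "known", "first", "only" and "open" are said of these compounds alone.

For the measured compounds named here, compound 3, `Cc1cccc(C#Cc2ccc3c(n2)CCN(C2CCCC2)C3=O)c1`, holds the lowest of the three numbers measured so far in an assay on HEK293 cells for displacement of a labelled ligand from metabotropic glutamate receptor 5 (Homo sapiens), with a stated time of 2 h (a lower number here means a stronger inhibitor, a higher number a weaker inhibitor), at 670 nM. Compound 1, `Cc1cccc(C#Cc2ccc3c(n2)CCN(C)C3=O)c1`, stands nearest to it; in this assay compound 1 gives 820 nM, and the step of a 1.2-fold lower number from compound 1 to compound 3 (0.09 log units; within the scatter) is too small to count. Compound 2, `CC(C)N1CCc2nc(C#Cc3ccccc3Cl)ccc2C1=O`, is furthest away; in this assay compound 2 gives 5680 nM, a gap beyond the scatter.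

Compound 4, `O=C1c2ccc(C#Cc3ccccc3Cl)nc2CCN1C1CCCC1`, differs from compound 3 by 2-chlorophenyl in place of 3-methylphenyl on a triple-bonded carbon. Going by the values given here, the only measured step, a 1.2-fold lower number from compound 1 to compound 3 (0.09 log units; within the scatter), concerns the group on the ring nitrogen and says nothing about the aryl group on the alkyne, so no single step bears directly on this change. Among the compounds with values here, compound 2 is the one measured compound that carries 2-chlorophenyl on the triple-bonded carbon, though it also carries isopropyl rather than cyclopentyl on the ring nitrogen, and its value of 5680 nM is the weakest of the three. Since the ring-nitrogen change between compound 1 and compound 3 moved little, the aryl change is expected to carry most of the rise, by about a 6.0-fold higher number from compound 3 to compound 4 (0.78 log units; beyond the scatter). Compound 4 is therefore expected to give roughly 4000 nM, within a range of 1500 nM to 10000 nM.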

Compound 4, inhibition constant: > 32000 nM
Compound 4: a limit, no number (the forecaster's own chance of this, stated with the estimate: 5%); middle value at least 8.0-fold (0.90 log units) away from the limit.
By their numbers in this assay, from the lowest: compounds 3 and 1 (each within the scatter of the next); then compound 2. At a limit, above all of these: compound 4.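

In this assay, for the compounds shown here, the aryl group on the triple-bonded carbon proves far more sensitive than the earlier compounds could show: 2-chlorophenyl in place of 3-methylphenyl gives an at least 47-fold higher number from compound 3 to compound 4 (1.67 log units; beyond the scatter), whereas the only earlier step, at the ring nitrogen, was a 1.2-fold lower number from compound 1 to compound 3 (0.09 log units; within the scatter). The reading for compound 4 is a limit of the assay and not a number: the limit of > 32000 nM in this assay, at which 1 of the 4 values shown sits. With 2-chlorophenyl on the triple-bonded carbon, the group on the ring nitrogen also matters, since cyclopentyl in place of isopropyl gives an at least 5.6-fold higher number from compound 2 to compound 4 (0.75 log units; beyond the scatter), so cyclopentyl is not tolerated equally with both aryl groups, although the two nitrogen changes start from different groups.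

The compounds shown leave open how an unsubstituted phenyl or a pyridyl group on the triple-bonded carbon would read, and so whether the rise follows the arrival of the chlorine or the loss of the methyl. The limit also leaves the full size of both new steps unknown, and a second ring-nitrogen group, such as cyclobutyl, could show how far this dependence on the nitrogen group extends.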